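The source may hold more compounds than are shown below. What is called first, only, known or untested is meant among the compounds shown, and "the series" means these compounds.

Compound 1 `COC(=O)c1cc(-c2ccccc2)cc(OC)c1C`: > 195000 nM
Compound 2 `C/C(=C\c1ccccc1)[C@@H](O)C(C)(C)C(=O)O`: > 213000 nM

In a functional assay on MCF7 cells (Homo sapiens) for cytotoxicity, read by resazurin assay (a higher number here means a weaker inhibitor, a lower number a stronger inhibitor), compound 1 gives > 195000 nM, which is a limit of the assay and not a number. In this assay compound 2 likewise gives > 213000 nM, also a limit rather than a number. Compound 2 thus stands at the limit of > 213000 nM in this assay, at which 1 of the 2 values shown sits. Among the measured compounds shown here, the only other value shown is the limit of > 195000 nM in this assay, at which 1 of the 2 values shown sits, so neither measured compound reaches a quantifiable inhibition here. Compound 3 `C/C(=C\c1ccccc1)[C@@H](O)C(C)(C)O` has not been measured in this assay. It differs from compound 2 by hydroxy in place of carboxy on a saturated chain carbon bound to three saturated chain carbons. For the measured compounds named here, no step between two measured compounds is available to calibrate this change, and in this assay no movement beyond the scatter is expected in either direction. Compound 3 is expected to remain at or beyond the same limit. Compound 3 is estimated at 250000 nM, within 60000 nM to 1000000 nM. The step from compound 2 to compound 3 is expected to be a step that the limit leaves unreadable from compound 2 to compound 3.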

Compound 3, half-maximal inhibitory concentration: > 242000 nM
Compound 3: only a limit was reported; the forecaster's own chance of this, stated with the estimate: 85%; the middle value does not contradict the limit.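

In this assay, compound 2 and compound 3 both give limits rather than numbers, so no step can be read for hydroxy in place of carboxy. The compounds shown leave open which change, if any, would bring a quantifiable inhibition in this assay.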